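Diaryl urea series: amine substituent and kinase inhibition

The source may hold more compounds than are shown below. What is called first, only, known or untested is meant among the compounds shown, and "the series" means these compounds.

Measured so far in an assay on isolated protein for inhibition of serine/threonine-protein kinase TNNI3K (Homo sapiens); on this read-out higher numbers stand for weaker inhibition and lower numbers for stronger inhibition:
- compound 1 `O=C(Nc1ccc(Oc2ccncn2)cc1)Nc1cccc(C(F)(F)F)c1` gives 160 nM
- compound 2 `CC(C)(O)CNc1cc(Oc2ccc(NC(=O)Nc3cccc(C(F)(F)F)c3)cc2)ncn1` gives 40 nM
- compound 3 `CN(C)c1cc(Oc2ccc(NC(=O)Nc3cccc(C(F)(F)F)c3)cc2)ncn1` gives 2500 nM

Compound 3 has the highest number of the three. Its nearest neighbour on the scale is compound 1, from which the step of a 16-fold higher number from compound 1 to compound 3 (1.19 log units; beyond the scatter) is large; against compound 2 it is larger still, a 63-fold higher number from compound 2 to compound 3 (1.80 log units; beyond the scatter). Compound 2 itself improves on compound 1 by a 4.0-fold lower number from compound 1 to compound 2 (0.60 log units; beyond the scatter).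

The next compound, compound 4 `CCNc1cc(Oc2ccc(NC(=O)Nc3cccc(C(F)(F)F)c3)cc2)ncn1`, differs from compound 3 only in one place: ethylamino in place of dimethylamino on an aromatic carbon. Both steps into compound 3 bear on this: adding dimethylamino onto the unsubstituted core of compound 1 cost a large amount, and exchanging the (2-hydroxy-2-methylpropyl)amino of compound 2 for dimethylamino cost even more. Compound 4 returns to a substituent of the type present in compound 2, so a large step back down is expected, roughly undoing the loss seen in a 63-fold higher number from compound 2 to compound 3 (1.80 log units; beyond the scatter), though the shorter ethyl chain may not recover the full benefit of compound 2. Compound 4 is therefore expected to show a 21-fold lower number from compound 3 to compound 4 (1.32 log units; beyond the scatter) in this assay. The estimate for compound 4 is 120 nM, with a range from 30 nM to 500 nM.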

Compound 4, half-maximal inhibitory concentration: 25 nM
Compound 4: the middle estimate sits 4.8-fold (0.68 log units) above what was measured; measured number outside the range, below it.
By their numbers in this assay, from the lowest: compounds 4 and 2 (each within the scatter of the next); then compound 1; then compound 3.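

Same atoms, different arrangement: in this assay the change from dimethylamino to ethylamino gives a 100-fold lower number from compound 3 to compound 4 (2.00 log units; beyond the scatter), so this pyrimidine position responds strongly to how its three heavy atoms are joined, not to their number, and the one counted difference is the hydrogen-bond donor that ethylamino carries and dimethylamino lacks. The 1-hydroxy-1-methylethyl end of compound 2 adds nothing that can be told apart from the methyl end of compound 4, with a 1.6-fold lower number from compound 2 to compound 4 (0.20 log units; within the scatter), so the gain over hydrogen does not depend on the hydroxyl-bearing chain in this pair. Ethylamino also improves on hydrogen, with a 6.4-fold lower number from compound 1 to compound 4 (0.81 log units; beyond the scatter), so among the substituents at this position compounds 2 and 4 gain over compound 1, while compound 3 goes against them.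

No measurement available here accounts for these steps.

As far as these compounds go, whether the donor itself or the shape of the amine drives the step stays open, and methylamino or an ether such as ethoxy would bear on that. From the compounds shown here alone, how far the chain can grow also stays open, as with propylamino, butylamino or a cyclic amine such as pyrrolidine.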